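Extending a Short Acyl Chain with an Oxane Ring

The source may report more compounds than this note shows. Statements on the series, on what has been measured and on what is new or still open speak of the compounds shown alone.

Of the compounds shown here, three sharing one core have been measured in an assay on HEK293 cells for negative allosteric modulation of metabotropic glutamate receptor 5 (Homo sapiens), read by FLIPR, with a stated time of 1 h; on this read-out lower numbers stand for stronger inhibition and higher numbers for weaker inhibition. Compound 1 `Fc1cccc(C#Cc2nc3c(s2)CN(C2CCOC2)CC3)c1` gives 400 nM. Compound 2 `CCC(=O)N1CCc2nc(C#Cc3ccccc3)sc2C1` gives 38 nM, the lowest of the two numbers shown, with compound 1 giving the higher one. Compound 3 `O=C(C1CC(F)(F)C1)N1CCc2nc(C#Cc3cccc(F)c3)sc2C1` reaches only the limit of the assay, > 10000 nM, and not a number. Among the compounds with values here, the single measured step between neighbours runs an at least 25-fold higher number from compound 1 to compound 3 (1.39 log units; beyond the scatter); its stated size rests on (the limit of > 10000 nM in this assay, at which 1 of the 3 values shown sits), so its true extent is not known.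

Compound 4 `O=C(CC1CCOCC1)N1CCc2nc(C#Cc3ccccc3)sc2C1` differs from compound 2 by one change: oxan-4-yl in place of methyl on a saturated chain carbon bound to a carbonyl carbon. Within the data shown here, no measured step touches this place: the step from compound 1 to compound 3 alters the group on the amine nitrogen in the ring, not the saturated chain carbon bound to the carbonyl carbon. The change adds a six-membered non-aromatic ring with one hetero atom to a chain that was short in compound 2, and nothing measured shows how this assay responds to growth at that position. The step is therefore expected to be small, a 2.1-fold higher number from compound 2 to compound 4 (0.32 log units; beyond the scatter), near the edge of the scatter and open in direction. Compound 4 is expected to give about 80 nM, within 20 nM to 400 nM.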

Compound 4, half-maximal inhibitory concentration: > 10000 nM
Compound 4 ended at the assay's limit; the forecaster's own chance of this, stated with the estimate: 5%; at least 120-fold (2.09 log units) between middle value and limit.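

In this assay, the saturated chain carbon bound to a carbonyl carbon turns out to be a place where this change matters greatly: oxan-4-yl in place of methyl gives an at least 260-fold higher number from compound 2 to compound 4 (2.42 log units; beyond the scatter). Within the data shown here, compound 4 gives > 10000 nM, which is a limit of the assay and not a number, so only the smallest possible size of this step is known: the limit of > 10000 nM in this assay, at which 2 of the 4 values shown sit. The earlier compounds offered no step at this place, and this pair now shows that the short chain of compound 2 cannot be extended with an oxane ring while keeping a measurable number.

What the compounds shown leave open is how much growth this place accepts, since a propyl or butyl chain on the same carbon would fall between the two groups compared here. They also do not separate the ring from its oxygen, and a cyclohexyl group, or a smaller ring such as cyclopropyl, at this place would show whether any ring gives the same loss or only the oxane does.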